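A smaller pyrimidine on the sulfonamide nitrogen

The source may report more compounds than this note shows. Statements on the series, on what has been measured and on what is new or still open speak of the compounds shown alone.

Compound 1 `Cc1cc(C)nc(NS(=O)(=O)c2ccc(Nc3nncc4ccccc34)cc2)n1`: 0.08 nM
Compound 2 `C(=C/c1ccccc1)\C(=N\Nc1nncc2ccccc12)c1ccccc1`: 0.01 nM

In a functional assay on SK-OV-3 cells (Homo sapiens) for antiproliferative activity, read by sulforhodamine B assay, with a stated time of 72 h (a higher number here means a weaker inhibitor, a lower number a stronger inhibitor), compound 1 gives 0.08 nM and compound 2 gives 0.01 nM on the same read-out. Compound 1 therefore holds the higher number of the two, and its gap to compound 2 lies beyond the usual scatter. Compound 3 `O=S(=O)(Nc1ncccn1)c1ccc(Nc2nncc3ccccc23)cc1` keeps the core of compound 1 but carries pyrimidin-2-yl in place of 4,6-dimethylpyrimidin-2-yl on a sulfonamide nitrogen. pyrimidin-2-yl in place of 4,6-dimethylpyrimidin-2-yl on a sulfonamide nitrogen is the counted change. Going by the values given here, no measured pair shows this change, so the data offer no direct guide to its size or direction, and no step beyond the scatter is expected. The estimate puts a 1.3-fold higher number from compound 1 to compound 3 (0.10 log units; within the scatter) within that scatter. Compound 3 is expected at 0.1 nM in this assay with an estimated range from 0.03 nM to 0.4 nM.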

Compound 3, half-maximal inhibitory concentration: 0.8 nM
Estimate against measurement, compound 3: 8.0-fold (0.90 log units) below, outside the stated range (above it).
By their numbers in this assay, from the lowest: compound 2; then compound 1; then compound 3.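

The change at this position is not silent in this assay and gives a 10-fold higher number from compound 1 to compound 3 (1.00 log units; beyond the scatter) with the core unchanged, so the sulfonamide nitrogen's substituent matters even though the two groups differ only slightly. Both groups are six-membered aromatic rings with the same counted hydrogen-bond donors and acceptors, and the step goes with the absence of the methyl groups of 4,6-dimethylpyrimidin-2-yl. Nothing measured here explains why the number rises.

The compounds shown leave open whether a single methyl group on the pyrimidin-2-yl ring would recover part of this step, and whether ethyl, methoxy or an amine on that ring would lower the number further. This single pair also cannot show whether the same change would act alike on another core.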